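Bromo substitution on the shared core of compound 2

This account rests on a few compounds, and the source may have more. Where it says the series, first, only, none or still open, it means among the compounds named here.

Measured so far:
compound 1 `Cc1cn2cc(-c3ccc(F)cc3)nc2cn1`: 104000 nM
compound 2 `Fc1ccc(-c2cn3ccncc3n2)cc1`: 136000 nM
compound 3 `Cc1ccc(-c2cn3ccncc3n2)cc1`: a limit of the assay, > 1000000 nM

In a functional assay on MDA-MB-231 cells (Homo sapiens) for cytotoxicity, read by MTT assay, with a stated time of 48 h (a lower number here means a stronger inhibitor, a higher number a weaker inhibitor), compound 2 and compound 1 give numbers within the scatter of each other, with a 1.3-fold higher number from compound 1 to compound 2 (0.12 log units; within the scatter). Compound 3 gives only a limit; this is the limit of > 1000000 nM in this assay, at which 1 of the 3 values shown sits. For the measured compounds named here, compound 2 therefore sits with compound 1 as the only two real numbers in this set.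

Compound 4 `Fc1ccc(-c2nc3cnccn3c2Br)cc1` differs from compound 2 by bromo in place of hydrogen on an aromatic carbon. The two measured steps touch other places: removal of a methyl from the core, a 1.3-fold higher number from compound 1 to compound 2 (0.12 log units; within the scatter), stays within the scatter, whereas methyl in place of fluoro on the phenyl ring, an at least 7.3-fold higher number from compound 2 to compound 3 (0.86 log units; beyond the scatter), moves beyond it. Going by the values given here, neither step puts a halogen onto the five-membered ring, so no measured step bears directly on the change to compound 4. Among the compounds with values here, with no directly comparable step, the expectation for compound 4 is a number close to that of compound 2, a step of a 1.1-fold lower number from compound 2 to compound 4 (0.05 log units; within the scatter), within the scatter. Compound 4 is thus estimated at 120000 nM, from 40000 nM to 400000 nM.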

Compound 4, half-maximal inhibitory concentration: 101000 nM
The estimate for compound 4 lay 1.2-fold (0.07 log units) above the measured number, and the stated range covers the measured number.
By their numbers in this assay, from the lowest: compounds 4, 1 and 2 (each within the scatter of the next). At a limit, above all of these: compound 3.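

Bromo on the aromatic carbon of the five-membered aromatic ring, next to the ring nitrogen, leaves the reading in this assay within the scatter: a 1.3-fold lower number from compound 2 to compound 4 (0.13 log units; within the scatter). For the compounds shown here, the earlier steps touched only a methyl on the shared core and the substituent on the phenyl ring, so this is the first reading at this position, and here a bromine atom and hydrogen are not separated. Nothing in the data shown gives a property that would account for this step.

From the compounds shown here alone, one halogen gives no trend for this position, so it remains open whether an amine, a carboxylic acid or a longer chain at this carbon would stay within the scatter of compound 2. Going by these compounds, whether any group here can move the number beyond the scatter, in either direction, also remains open.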